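Swapping a thiophene for a pyridine on the shared core

The source may hold more compounds than are shown below. What is called first, only, known or untested is meant among the compounds shown, and "the series" means these compounds.

Three compounds share one core and differ in where the hydroxyl groups sit on the flanking phenyl rings. In a functional assay on HeLa cells (Homo sapiens) for cytotoxicity, read by CCK-8 assay (a higher number here means a weaker inhibitor, a lower number a stronger inhibitor), compound 2 `Oc1ccc(-c2cc(-c3ccsc3)cc(-c3cccc(O)c3)n2)cc1` gives 2580 nM, the lowest of the two numbers reported. Compound 3 `Oc1ccc(-c2cc(-c3ccsc3)cc(-c3ccc(O)cc3)n2)cc1` gives 4370 nM in this assay, and the step of a 1.7-fold higher number from compound 2 to compound 3 (0.23 log units; within the scatter) leaves the two indistinguishable. Among the compounds with values here, compound 1 `Oc1cccc(-c2cc(-c3ccsc3)cc(-c3ccccc3O)n2)c1` gives only a limit of the assay, > 50000 nM, so the step of an at least 19-fold lower number from compound 1 to compound 2 (1.28 log units; beyond the scatter) is the one large change seen here.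

Compound 4 `Oc1ccc(-c2cc(-c3cccnc3)cc(-c3cccc(O)c3)n2)cc1` keeps the hydroxyphenyl arrangement of compound 2 and changes the third ring: pyridin-3-yl in place of thiophen-3-yl on an aromatic carbon. Neither measured step touches this position; both concern the hydroxyphenyl groups, so there is no direct guide. With nothing to indicate a shift, the step from compound 2 is expected to stay within the scatter, and compound 4 is estimated at 3000 nM, between 1000 nM and 9000 nM, meaning an expected step of a 1.2-fold higher number from compound 2 to compound 4 (0.07 log units; within the scatter).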

Compound 4, half-maximal inhibitory concentration: > 50000 nM
Compound 4: only a limit was reported; the forecaster's own chance of this, stated with the estimate: 10%; at least 16-fold (1.22 log units) between middle value and limit.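

Within the data shown here, until this result, only the hydroxyphenyl groups had been seen to move the number, but the ring opposite the ring nitrogen of the shared core matters too: pyridin-3-yl in place of thiophen-3-yl gives an at least 19-fold higher number from compound 2 to compound 4 (1.28 log units; beyond the scatter) in this assay. With this change, the arrangement of hydroxyphenyl groups in compound 2 no longer secures a measurable number on its own. The reading for compound 4 is a limit of the assay and not a number, so the step has only a minimum size, and compound 1 carries the same limit: the limit of > 50000 nM in this assay, at which 2 of the 4 values shown sit.

The change swaps a five-membered ring with sulfur for a six-membered ring with nitrogen, and these compounds do not separate ring size from the hetero atom. Going by these compounds, how a plain phenyl, a furan-3-yl or an aminomethyl group would read at this position remains open.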